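From Amine to a Larger Nitrogen Chain on Compound 1

The source may hold more compounds than are shown below. What is called first, only, known or untested is meant among the compounds shown, and "the series" means these compounds.

Three compounds were measured in an assay on CHO cells for displacement of a labelled ligand from somatostatin receptor type 4 (Homo sapiens); on this read-out higher numbers stand for weaker inhibition and lower numbers for stronger inhibition:
compound 1 `CS[C@@H]1O[C@H](COCc2ccc(Cl)cc2)[C@@H](O)[C@@H](OCc2ccc3ccccc3c2)[C@H]1NC(=O)CCN`, 430 nM;
compound 2 `CS[C@@H]1O[C@H](COCc2ccc3ccccc3c2)[C@@H](O)[C@@H](OCc2ccc3ccccc3c2)[C@H]1NC(=O)CCN`, 440 nM;
compound 3 `CS[C@@H]1O[C@H](COCc2ccccc2)[C@@H](O)[C@@H](OCc2ccc3ccccc3c2)[C@H]1NC(=O)CCN`, 660 nM.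

Compound 1 gives the lowest number of the three, yet the steps of a 1.0-fold higher number from compound 1 to compound 2 (0.01 log units; within the scatter) and a 1.5-fold higher number from compound 1 to compound 3 (0.19 log units; within the scatter) both lie within the scatter, so no ranking among them holds. Compound 4 `CS[C@@H]1O[C@H](COCc2ccc(Cl)cc2)[C@@H](O)[C@@H](OCc2ccc3ccccc3c2)[C@H]1NC(=O)CCCN=C(N)N` differs from compound 1 in the amide side chain: a group of 5 heavy atoms (2 carbon, 3 nitrogen; no ring) in place of one nitrogen atom, on a saturated chain carbon, two bonds along the chain from a carbonyl carbon. Within the data shown here, none of the measured steps touches this chain; all of them exchange the aryl groups on the ether oxygens and stay within the scatter. Among the measured compounds shown here, there is thus no measured step that bears on the change, and in this assay compound 4 is expected to show no change at the digits printed from compound 1 to compound 4 (within the scatter), with a wide margin. Compound 4 is estimated at 430 nM, ranging from 130 nM to 1400 nM.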

Compound 4, half-maximal inhibitory concentration: 720 nM
Compound 4: middle estimate off by 1.7-fold (0.22 log units), on the low side, within the range that was stated.
By their numbers in this assay, from the lowest: compounds 1, 2, 3 and 4 (each within the scatter of the next).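

In this assay, among these compounds, the first change at this chain position gives a 1.7-fold higher number from compound 1 to compound 4 (0.22 log units; within the scatter) and so stays inside the scatter, like the earlier exchanges of aryl groups. At this place, on a saturated chain carbon, two bonds along the chain from a carbonyl carbon, the amino group and the larger group of 5 heavy atoms therefore cannot be told apart. Nothing available offers an explanation for this result.

As far as these compounds go, whether a carboxylic acid or a longer chain at this place would also stay inside the scatter remains open. Also open, from the compounds shown here alone, is whether the same exchange would read alike on compound 2 and compound 3.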